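This account rests on a few compounds, and the source may have more. Where it says the series, first, only, none or still open, it means among the compounds named here.

In a functional assay on SGC-7901 cells (Homo sapiens) for inhibition, read by MTT assay, with a stated time of 72 h (on this read-out higher numbers stand for weaker inhibition and lower numbers for stronger inhibition), compound 1 `O=C1Nc2ccccc2/C1=C\C(=O)c1cccc(Cl)c1` gives 8400 nM and compound 2 `O=C1Nc2ccccc2/C1=C\C(=O)c1cc(F)cc(F)c1` gives 17600 nM as its reading. Among the compounds with values here, compound 1 therefore has the lower of the only two numbers available, and the gap between them lies just beyond the usual scatter of repeated measurements. These two compounds do not differ in just one place, so their gap cannot be tied to any single group.

Compound 3 `CCC(=O)Nc1cccc(C(=O)/C=C2/C(=O)Nc3ccccc32)c1` keeps the core of compound 1 but carries propanoylamino in place of chloro on an aromatic carbon, meta to a large group (propanoylamino in place of chloro on an aromatic carbon). Within the data shown here, no measured pair shows what a single swap at this place does, so the size of the step remains a judgement. In this assay, among the measured compounds shown here, the expectation is no step beyond the scatter, with a slight lean towards a higher number, since the only other measured compound, compound 2 at 17600 nM on this scale, lies on the higher side of compound 1. The estimated 1.4-fold higher number from compound 1 to compound 3 (0.15 log units; within the scatter) stays within that scatter. For compound 3 the estimated value is 12000 nM with an expected range from 3500 nM to 40000 nM in this test.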

Compound 3, half-maximal inhibitory concentration: 11500 nM
The estimate for compound 3 lay 1.0-fold (0.02 log units) above the measured number; the range from low to high includes it.
By their numbers in this assay, from the lowest: compounds 1, 3 and 2 (each within the scatter of the next, the first and the last beyond it).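

In this assay, within the data shown here, replacing chloro with propanoylamino gives the first step that can be read for a single change at this place on the aromatic ring: a 1.4-fold higher number from compound 1 to compound 3 (0.14 log units; within the scatter) and this step stays within the scatter. The entering group is much bigger than the one it replaces, with 5 heavy atoms against 1, and it brings a hydrogen-bond donor and a hydrogen-bond acceptor that chloro lacks, yet the readings of the two compounds cannot be told apart in this cell test. No measurement shown here explains why these two readings stay so close.

This is still one swap at one place, so it cannot show whether the same holds for other groups, and an amine, a carboxylic acid or a longer acyl chain on this aromatic carbon could give quite a different reading. From the compounds shown here alone, compound 2 differs from compound 1 in more than one place, so it offers no second view of this position, and whether the amide link or the chain of propanoylamino matters more remains open.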